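Triazolopyrimidine amine series: hydroxypropyl step at the fluorobenzyl core

This account rests on a few compounds, and the source may have more. Where it says the series, first, only, none or still open, it means among the compounds named here.

Measured so far in an assay on isolated protein for binding affinity to adenosine receptor A1 (Bos taurus); on this read-out lower numbers stand for stronger inhibition and higher numbers for weaker inhibition:
compound 1 `CC(O)CNc1nc(-c2ccccc2)nc2c1nnn2Cc1ccccc1Cl` gives 32000000 nM
compound 2 `Fc1ccccc1Cn1nnc2c(NC3CCCCC3)nc(-c3ccccc3)nc21` gives 1150000 nM
compound 3 `CCNc1nc(-c2ccccc2)nc2c1nnn2Cc1ccccc1F` gives 11000000 nM

Compound 3 holds the second highest number of the three. Its nearest neighbour is compound 1, whose number is higher; compound 2 is the furthest, with a lower number, and the step of a 9.6-fold higher number from compound 2 to compound 3 (0.98 log units; beyond the scatter) shows what replacing cyclohexyl by ethyl on the nitrogen on the aromatic ring does. Compound 4 `CC(O)CNc1nc(-c2ccccc2)nc2c1nnn2Cc1ccccc1F` has not been measured. Set against compound 3, the change is 1-hydroxyethyl in place of methyl on a saturated chain carbon bound to a nitrogen on an aromatic ring.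

Going by the values given here, only one measured step exists, and it does not touch the chain beyond the first carbon on that nitrogen, so it bears on compound 4 only indirectly, as a sign that the amine substituent moves this read-out by a modest amount. Compound 1 carries the same 2-hydroxypropyl chain as compound 4 but differs from compound 3 in two places, so its value can only be set beside that of compound 3: the number for compound 1 is higher. On that basis a modest rise in the number is expected, without great confidence. Compound 4 is estimated at 22000000 nM in this assay, within 7000000 nM to 70000000 nM, an expected step of a 2.0-fold higher number from compound 3 to compound 4 (0.30 log units; within the scatter).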

Compound 4, inhibition constant: 4800000 nM
Beside the measured number, compound 4's estimate is 4.6-fold (0.66 log units) above it; measured number outside the range, below it.
By their numbers in this assay, from the lowest: compound 2; then compound 4; then compound 3; then compound 1.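

In this assay, going by these compounds alone, 1-hydroxyethyl in place of methyl on a saturated chain carbon bound to a nitrogen on an aromatic ring gives a 2.3-fold lower number from compound 3 to compound 4 (0.36 log units; beyond the scatter), the first reading of a change further out on this chain, and the number falls. The 2-hydroxypropyl chain still leaves the series short of the cyclohexyl compound, with a 4.2-fold higher number from compound 2 to compound 4 (0.62 log units; beyond the scatter), so compound 2 keeps the lowest number of the four. Within the data shown here, compound 4 also gives the first single-place reading of the aromatic halogen: fluoro in place of chloro on an aromatic carbon, with the 2-hydroxypropyl chain held constant, gives a 6.7-fold lower number from compound 1 to compound 4 (0.82 log units; beyond the scatter). No supporting data bear on the reason for these steps, and they stand as observations only.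

Open, from the compounds shown here alone, is whether the lower number goes with the oxygen or with the longer chain, which a plain propyl group on the same nitrogen would separate. Also open, going by these compounds, are the outcome with an amine or a carboxylic acid in place of the hydroxyl, and whether the fluoro-for-chloro step holds with ethyl or cyclohexyl on that nitrogen.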